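Two limits and one open step

The source may report more compounds than this note shows. Statements on the series, on what has been measured and on what is new or still open speak of the compounds shown alone.

Compound 1 `Cc1ccc(C2=NN(c3ccc(S(C)(=O)=O)cc3)C(=O)CC2)cc1`: > 100000 nM, a limit
Compound 2 `Cc1cc(O)ccc1C1=NN(c2ccc(S(C)(=O)=O)cc2)C(=O)CC1`: > 100000 nM, a limit

In a functional assay on SR cells (Homo sapiens) for inhibition, read by sulforhodamine B assay, with a stated time of 48 h (on this read-out higher numbers stand for weaker inhibition of growth and lower numbers for stronger inhibition of growth), compound 2 gives > 100000 nM, which is a limit of the assay and not a number. Compound 1 gives > 100000 nM, which is likewise only a limit. The whole picture so far is therefore (the limit of > 100000 nM in this assay, at which 2 of the 2 values shown sit).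

The next compound is compound 3 `CCc1ccc(C2=NN(c3ccc(S(C)(=O)=O)cc3)C(=O)CC2)cc1`. The change is 4-ethylphenyl in place of 4-hydroxy-2-methylphenyl on a carbon with a double bond to nitrogen. It takes place on the carbon with a double bond to nitrogen, where 4-ethylphenyl now stands in place of 4-hydroxy-2-methylphenyl.

Going by the values given here, only one measured step touches this place: a step that the two limits leave unreadable from compound 1 to compound 2. It offers no size to carry over, so the data hold no measured shift for a swap of this kind. With compound 1 and compound 2 both at a limit, nothing points towards stronger or weaker inhibition of growth. No step beyond the usual scatter is expected in this assay, although a number under the limit remains possible.

The expected step is a number no higher from compound 2 to compound 3 (the limit leaves the size open). Compound 3 is estimated at 100000 nM, with an expected range of 30000 nM to 100000 nM.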

Compound 3, concentration for total growth inhibition: 40300 nM
Estimate against measurement, compound 3: 2.5-fold (0.39 log units) above; low and high end bracket the measured number.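

In this assay, going by these compounds alone, compound 3 is the first compound to give a true number, so a change on the carbon with a double bond to nitrogen can now be read: 4-ethylphenyl in place of 4-hydroxy-2-methylphenyl gives an at least 2.4-fold lower number from compound 2 to compound 3 (0.39 log units; beyond the scatter). The smaller change, methyl in place of hydrogen on a saturated chain carbon bound to an aromatic carbon, turns the 4-methylphenyl group of compound 1 into 4-ethylphenyl and gives an at least 2.4-fold lower number from compound 1 to compound 3 (0.39 log units; beyond the scatter), so this one added methyl is enough to bring the result under the limit. Both sizes are only minimums, and the step from compound 1 to compound 2 cannot be read: the limit of > 100000 nM in this assay, at which 2 of the 3 values shown sit.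

The compounds shown leave open whether growth inhibition keeps strengthening when the ethyl group gives way to a longer chain such as propyl or butyl, or whether an amine at the end of such a chain would keep the effect. They also cannot separate the parts of the change from 4-hydroxy-2-methylphenyl to 4-ethylphenyl, where the hydroxy group, the methyl group and the ethyl group all differ in a single step.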